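Ester-to-acid step on a tetrahydropyranyl enoate series

The compounds below may be only part of what the source reports. "The series", "measured", "known", "first", "only" and "open" are said of these compounds alone.

Compound 1 `CC(C)(C)[Si](C)(C)O[C@@H]1CCCO[C@@H]1/C=C\C(=O)OCc1ccccc1` and compound 2 `COC(=O)/C=C\[C@H]1OCCC[C@H]1O[Si](C)(C)C(C)(C)C` share the protected cyclic core and differ only in the ester group. In a functional assay on WiDr cells (Homo sapiens) for antiproliferative activity, read by sulforhodamine B assay, with a stated time of 48 h (on this read-out higher numbers stand for weaker inhibition of growth and lower numbers for stronger inhibition of growth), compound 1 gives 20000 nM, and compound 2 gives 38000 nM. Compound 2 has the higher of the two numbers, yet the step of a 1.9-fold higher number from compound 1 to compound 2 (0.28 log units; within the scatter) is within the scatter, so the two compounds cannot be told apart on this read-out.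

Compound 3 `CC(C)(C)[Si](C)(C)O[C@@H]1CCCO[C@@H]1/C=C/C(=O)O` is the next member. Relative to compound 2 the change is 2-carboxyethenyl in place of 2-(methoxycarbonyl)ethenyl on a saturated ring carbon. For the measured compounds named here, the only measured step that touches the same part of the molecule, from compound 1 to compound 2, swapped one ester alcohol for another and produced a 1.9-fold higher number from compound 1 to compound 2 (0.28 log units; within the scatter), which gives no sign that this region controls the read-out. Going by the values given here, a free acid in place of the ester has no precedent among the measured compounds, so the expectation rests on the weak activity of both neighbours. Compound 3 is therefore expected to sit near the same level, with a step of a 1.3-fold higher number from compound 2 to compound 3 (0.12 log units; within the scatter) that is estimated to stay within the scatter, and an estimated value of 50000 nM (range 15000 nM to 200000 nM).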

Compound 3, concentration for 50% growth inhibition: > 100000 nM
Compound 3: no number, only a limit; the forecaster's own chance of this, stated with the estimate: 30%; at least 2.0-fold (0.30 log units) between middle value and limit.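

In this assay compound 3 gives > 100000 nM, which is a limit of the assay and not a number. The earlier swap of one ester alcohol for another stayed within the scatter (a 1.9-fold higher number from compound 1 to compound 2 (0.28 log units; within the scatter)), whereas 2-carboxyethenyl in place of 2-(methoxycarbonyl)ethenyl on this saturated ring carbon gives an at least 2.6-fold higher number from compound 2 to compound 3 (0.42 log units; beyond the scatter), the first sign that the read-out responds to a change at this position. From the compounds shown here alone, the true size of this step remains unknown, as the value for compound 3 is only a bound and the read-out gives no number there: the limit of > 100000 nM in this assay, at which 1 of the 3 values shown sits.

As drawn, compound 3 also has the opposite double-bond geometry to compound 2, so the compounds shown do not separate the effect of the free carboxylic acid from that of the geometry. Going by these compounds, it also remains open whether a primary amide in place of the ester, or a free hydroxyl in place of the tert-butyldimethylsilyl ether, would move the read-out in either direction.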